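A few compounds are considered here, and "the series" means these few. Any claim that something is new, unique, unknown or untested is made for them only; others in the source may bear on it.

Three esters built on one shared core have been examined. Compound 2, `CC1=CC[C@H](C(C)C)c2cc(C)c(OC(=O)c3ccc(Cl)cc3)cc21`, carries a 4-chlorophenyl group on the carbonyl carbon; in a functional assay on MCF7 cells (Homo sapiens) for antiproliferative activity, read by sulforhodamine B assay, with a stated time of 48 h, tested at 50 uM (a lower number here means less inhibition, a higher number more inhibition at the concentration tested (going by the name of the read-out)), compound 2 gives 79.7%. Compound 1, `CC1=CC[C@H](C(C)C)c2cc(C)c(OC(=O)c3ccc(C(F)(F)F)cc3)cc21`, differs from it by trifluoromethyl in place of chloro on an aromatic carbon, and in this assay compound 1 gives 40.4%, which makes the step of a number 39.3 percentage points lower from compound 2 to compound 1 (beyond the scatter). Compound 3, `CC1=CC[C@H](C(C)C)c2cc(C)c(OC(=O)c3cccc(Cl)c3)cc21`, has the same atoms as compound 2 joined differently: 3-chlorophenyl in place of 4-chlorophenyl on a carbonyl carbon. In this assay compound 3 gives 40.4%, so the step is a number 39.3 percentage points lower from compound 2 to compound 3 (beyond the scatter). Compound 3 and compound 1 stand level at the digits reported, and together they are the lowest of the three numbers.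

Compound 4, `CC1=CC[C@H](C(C)C)c2cc(C)c(OC(=O)c3cccc(C(F)(F)F)c3)cc21`, has not yet been measured. It differs from compound 3 by trifluoromethyl in place of chloro on an aromatic carbon. This is the same kind of change as the one made from compound 2 to compound 1, and it occurs twice among these compounds, but the place is not the same word for word: in compound 1 the trifluoromethyl sits para to a large group, whereas in compound 4 it sits meta to a large group. The earlier step was a number 39.3 percentage points lower from compound 2 to compound 1 (beyond the scatter). For compound 4 a smaller step is expected, a number 18.4 percentage points lower from compound 3 to compound 4 (beyond the scatter), because compound 3 already gives 40.4% and a fall of the earlier size would leave almost no inhibition. The shift of the place from para to meta is untested among these compounds. In this assay compound 4 is therefore estimated at 22%, most likely between 5% and 42%.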

Compound 4, a percentage reported as inhibition, at one concentration (the size of the read-out at that concentration, not a potency): 86%
The estimate for compound 4 lay 64 percentage points below the measured number; measured number above the stated range.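

In this assay, replacing chloro with trifluoromethyl on an aromatic carbon gives a number 45.6 percentage points higher from compound 3 to compound 4 (beyond the scatter). Set beside the earlier step, the same change does not carry from one core to the other, either in direction or in size: the same change on two cores in this assay, a number 39.3 percentage points lower (beyond the scatter) from compound 2 to compound 1 and a number 45.6 percentage points higher (beyond the scatter) from compound 3 to compound 4, 84.9 percentage points apart, beyond the scatter of two such steps. So among these four compounds, a result for this change in one pair cannot be used to predict the other pair, but two pairs show only a single reversal; they establish no rule for the series, give no reason for the reversal, and, as each number is a reading at one concentration, say nothing about potency.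

The compounds shown leave open whether the reversal extends to other groups on this aromatic ring, such as a nitrile, a methoxy group, an amine or a carboxylic acid, since only chloro and trifluoromethyl appear here. They also leave open whether it would persist if the ester link shared by all four compounds were replaced by an amide, or if the isopropyl group on the shared core were replaced by a longer chain.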